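This account rests on a few compounds, and the source may have more. Where it says the series, first, only, none or still open, it means among the compounds named here.

In a functional assay on CCRF-CEM cells (Homo sapiens), read by MTT assay, with a stated time of 72 h (on this read-out higher numbers stand for weaker inhibition and lower numbers for stronger inhibition), compound 2 `COc1nc(N)nc2c1c(-c1ccsc1)cn2[C@@H]1O[C@H](CO)[C@@H](O)[C@H]1O` gives only a limit, > 20000 nM. Compound 1 `Nc1nc(N)c2c(-c3ccsc3)cn([C@@H]3O[C@H](CO)[C@@H](O)[C@H]3O)c2n1` likewise gives only a limit in this assay, > 20000 nM. The step that the two limits leave unreadable from compound 1 to compound 2 cannot be sized because both values sit at a limit (the limit of > 20000 nM in this assay, at which 2 of the 2 values shown sit). Compound 3 `COc1nc(N)nc2c1c(-c1cccs1)cn2[C@@H]1O[C@H](CO)[C@@H](O)[C@H]1O` differs from compound 2 by thiophen-2-yl in place of thiophen-3-yl on an aromatic carbon. Within the data shown here, no measured step covers this change, and neither measured compound shows inhibition that can be read as a number. Compound 3 is therefore expected to stay at the same limit, so that a step that the limit leaves unreadable from compound 2 to compound 3 is an expectation of no change. Compound 3 is estimated at 30000 nM, with a range from 10000 nM to 100000 nM.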

Compound 3, half-maximal inhibitory concentration: > 20000 nM
Compound 3: only a limit was reported; the forecaster's own chance of this, stated with the estimate: 85%; the middle value does not contradict the limit.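

No new step can be read from compound 2 to compound 3, since both give only a limit: the limit of > 20000 nM in this assay, at which 3 of the 3 values shown sit. In this assay the compounds shown leave open which change, if any, would give inhibition readable as a number.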